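The source may hold more compounds than are shown below. What is called first, only, known or untested is meant among the compounds shown, and "the series" means these compounds.

The measured compounds in this study are:

compound 1, `O=C(/C=C/c1ccc(O)c(O)c1)N1CCN(c2ccc(F)cc2)CC1`, with 1.25 ug/mL in a functional assay on A549 cells (Homo sapiens) for antiproliferative activity, read by MTT assay, with a stated time of 48 h; on this read-out higher numbers stand for weaker inhibition and lower numbers for stronger inhibition;
compound 2, `O=C(/C=C/c1ccc(O)c(O)c1)N1CCN(c2ccc([N+](=O)[O-])cc2)CC1`, with 1.56 ug/mL;
compound 3, `Cc1ccc(N2CCN(C(=O)/C=C/c3ccc(O)c(O)c3)CC2)c(C)c1`, with 1.02 ug/mL.

Among these three numbers compound 1 stands second highest. Its nearest neighbour is compound 3, reached by a 1.2-fold lower number from compound 1 to compound 3 (0.09 log units; within the scatter), and its furthest is compound 2, reached by a 1.2-fold higher number from compound 1 to compound 2 (0.10 log units; within the scatter); both steps lie within the scatter, so the three compounds cannot be ordered on these data.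

Compound 4, `O=C(/C=C/c1ccc(O)c(O)c1)N1CCN(c2ccc(Cl)c(Cl)c2)CC1`, has not yet been measured. It differs from compound 1 in one place: 3,4-dichlorophenyl in place of 4-fluorophenyl on an amine nitrogen in a ring.

Among the measured compounds shown here, two measured steps concern the same place, the group on the amine nitrogen in the ring: a 1.2-fold lower number from compound 1 to compound 3 (0.09 log units; within the scatter) and a 1.5-fold lower number from compound 2 to compound 3 (0.18 log units; within the scatter). Neither moved the number beyond the scatter, and the change on the aromatic carbon, a 1.2-fold higher number from compound 1 to compound 2 (0.10 log units; within the scatter), was likewise small. On this basis no step beyond the scatter is expected from compound 1 to compound 4: the estimated step is a 1.0-fold lower number from compound 1 to compound 4 (0.02 log units; within the scatter).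

Compound 4 is therefore estimated at 1.2 ug/mL, with an expected range from 0.6 ug/mL to 2.5 ug/mL.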

Compound 4, half-maximal inhibitory concentration: 1.74 ug/mL
Compound 4: middle estimate off by 1.5-fold (0.16 log units), on the low side; measured number inside the range.
By their numbers in this assay, from the lowest: compounds 3, 1, 2 and 4 (each within the scatter of the next).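

In this assay, the swap of 4-fluorophenyl for 3,4-dichlorophenyl on the amine nitrogen gives a 1.4-fold higher number from compound 1 to compound 4 (0.14 log units; within the scatter), so a ring carrying two chlorine atoms stays within the scatter of the ring carrying one fluorine. The same holds against the other two compounds, with a 1.7-fold higher number from compound 3 to compound 4 (0.23 log units; within the scatter) and a 1.1-fold higher number from compound 2 to compound 4 (0.05 log units; within the scatter), so all four substituted phenyl groups at this position give numbers that cannot be ordered. Nothing measured here explains why this position tolerates these groups.

The compounds shown all keep a phenyl ring on this nitrogen, so it remains open whether a cyclohexyl group, a pyridine ring or a simple methyl group would hold the number. On these data alone, it also remains open whether the two hydroxyl groups of the shared core could be exchanged for methoxy groups.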